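Extending the sulfonyl substituent of a stable acyl sulfonamide

The source may report more compounds than this note shows. Statements on the series, on what has been measured and on what is new or still open speak of the compounds shown alone.

Compound 1 `CC(C)S(=O)(=O)NC(=O)c1ccc(Nc2nc(NC3(c4ccc(Cl)cc4)CC3)nc(OCC(F)(F)F)n2)cc1` is measured in an ADME assay on microsomes from liver (Homo sapiens) for metabolic stability, with a stated time of 10 min (on this read-out higher numbers stand for a more stable compound and lower numbers for a less stable compound), and gives 100%, level with compound 3 `CC(C)NC(=O)NCCS(=O)(=O)NC(=O)c1ccc(Nc2nc(NC3(c4ccc(Cl)cc4)CC3)nc(OCC(F)(F)F)n2)cc1`, which gives 100%, and together they are the highest of the three numbers. Compound 2 `CC(C)NCCS(=O)(=O)NC(=O)c1ccc(Nc2nc(NC3(c4ccc(Cl)cc4)CC3)nc(OCC(F)(F)F)n2)cc1` gives 89%. The step of no change at the digits printed from compound 1 to compound 3 (within the scatter) lies within the scatter, while a number 11 percentage points lower from compound 1 to compound 2 (beyond the scatter) is a modest loss, and a number 11 percentage points higher from compound 2 to compound 3 (beyond the scatter) recovers it. Compound 4 `COC(=O)NCCS(=O)(=O)NC(=O)c1ccc(Nc2nc(NC3(c4ccc(Cl)cc4)CC3)nc(OCC(F)(F)F)n2)cc1` differs from compound 1 by 2-((methoxycarbonyl)amino)ethyl in place of isopropyl on a sulfonyl sulfur. Among the measured compounds shown here, this change most resembles the one from compound 1 to compound 3, which showed no change, so only a small step or none beyond the scatter is expected, a number 4 percentage points lower from compound 1 to compound 4 (within the scatter). Compound 4 is therefore estimated at 96%, within 84% to 100%.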

Compound 4, percent of the compound remaining: 90%
The estimate for compound 4 lay 6 percentage points above the measured number; the measured number falls inside the stated range.
By their numbers in this assay, from the lowest: compounds 2, 4, 1 and 3 (each within the scatter of the next, the first and the last beyond it).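

In this assay the 2-((methoxycarbonyl)amino)ethyl group on the sulfonyl sulfur gives a number 10 percentage points lower from compound 1 to compound 4 (within the scatter) and methoxy in place of isopropylamino on the carbonyl carbon gives a number 10 percentage points lower from compound 3 to compound 4 (within the scatter) in the same read-out. Methoxycarbonyl in place of isopropyl on the amine nitrogen gives a number 1 percentage points higher from compound 2 to compound 4 (within the scatter) and so compound 4 cannot be told apart from compounds 1, 2 or 3, even though compounds 2 and 3 lie beyond the scatter of each other. Nothing available explains these numbers. On these data alone, whether a carboxylic acid or a longer chain on the sulfonyl sulfur would hold the number at this level remains open.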